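This account rests on a few compounds, and the source may have more. Where it says the series, first, only, none or still open, it means among the compounds named here.

Of the compounds shown here, three have so far been measured in an ADME assay on MRC5 cells (Homo sapiens) for cytotoxicity, read by MTT assay; a lower number here means that less compound is tolerated, a higher number that more compound is tolerated. Compound 1 `O=c1[nH]cc(C#CC2CCCCC2)c(=O)[nH]1` gives 62800 nM, compound 2 `CCC#Cc1c[nH]c(=O)[nH]c1=O` gives 120000 nM, and compound 3 `CCCCC#Cc1cn([C@@H]2O[C@H](CO)[C@@H](O)[C@H]2O)c(=O)[nH]c1=O` gives 11600 nM. Compound 3 therefore stands lowest of the three numbers in this assay: the nearest number, that of compound 1, lies higher by a margin beyond the scatter, and the number of compound 2 lies higher still, also beyond the scatter. Of these three, compound 3 is the one of which least is tolerated.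

Compound 4 `O=c1[nH]c(=O)n([C@@H]2O[C@H](CO)[C@@H](O)[C@H]2O)cc1C#Cc1ccccc1` differs from compound 3 in a single place: phenyl in place of butyl on a triple-bonded carbon. The rest of the structure is unchanged. Among the compounds with values here, none of the measured compounds shows what this swap does in this assay, so the expectation rests on compound 3 alone. Only a modest step is expected, if any beyond the scatter, leaning toward a lower number: a 1.5-fold lower number from compound 3 to compound 4 (0.16 log units; within the scatter). Compound 4 is accordingly expected to give about 8000 nM, somewhere between 2500 nM and 25000 nM.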

Compound 4, half-maximal cytotoxic concentration: 1200 nM
Compound 4: the middle estimate sits 6.7-fold (0.82 log units) above what was measured; measured number outside the range, below it.
By their numbers in this assay, from the lowest: compound 4; then compound 3; then compounds 1 and 2 (each within the scatter of the next).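

On a triple-bonded carbon of the shared core, phenyl in place of butyl gives a 9.7-fold lower number from compound 3 to compound 4 (0.99 log units; beyond the scatter) in this assay, a step beyond the scatter. Within the data shown here, until now no step between measured compounds could be read, so this pair gives the first direct view of this position: what sits on this carbon can by itself change how much compound is tolerated, and here less is tolerated with phenyl than with butyl. Nothing at hand explains the size of this step.

Still open, as far as these compounds go, is whether it is the ring itself or simply the larger group that counts, and a longer chain such as octyl or a chain ending in an amine on the same carbon could help to separate these. Also open, from the compounds shown here alone, is whether phenyl would bring a similar step on the core of compound 2.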